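Swapping the Aryl Group of Compound 3

The compounds below may be only part of what the source reports. "The series", "measured", "known", "first", "only" and "open" are said of these compounds alone.

Three compounds share one core and differ only in the aromatic ring that sits on an amide-type nitrogen. Compound 1 `Cc1ccc(NC(=O)Nc2nnc(Sc3ncnc4scc(-c5ccncc5)c34)s2)cc1` carries a 4-methylphenyl group, and in a functional assay on HepG2 cells (Homo sapiens) for antiproliferative activity, read by MTT assay, with a stated time of 48 h (a higher number here means a weaker inhibitor, a lower number a stronger inhibitor), compound 1 gives 52000 nM. Compound 2 `O=C(Nc1ccc(Cl)cc1)Nc1nnc(Sc2ncnc3scc(-c4ccncc4)c23)s1` differs from it by a chloro in place of the methyl on an aromatic carbon, and in this assay compound 2 gives 28900 nM; the change reads as a 1.8-fold lower number from compound 1 to compound 2 (0.26 log units; within the scatter). Compound 3 `O=C(Nc1ccc(Cl)c(C(F)(F)F)c1)Nc1nnc(Sc2ncnc3scc(-c4ccncc4)c23)s1` carries a 4-chloro-3-(trifluoromethyl)phenyl group, and in this assay compound 3 gives 45300 nM, the second highest of the three numbers, nearest to compound 1 and furthest from compound 2. Its steps read a 1.1-fold lower number from compound 1 to compound 3 (0.06 log units; within the scatter) and a 1.6-fold higher number from compound 2 to compound 3 (0.20 log units; within the scatter), so every swap of this aromatic ring so far has left the readout essentially unchanged.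

Compound 4 `COc1cccc(NC(=O)Nc2nnc(Sc3ncnc4scc(-c5ccncc5)c34)s2)c1` is the next such swap: 3-methoxyphenyl in place of 4-chloro-3-(trifluoromethyl)phenyl on an amide-type nitrogen. All three measured steps exchange substituents on the same ring. All of them lie within the scatter. No step beyond the scatter is therefore expected, and the estimated change is a 1.1-fold lower number from compound 3 to compound 4 (0.03 log units; within the scatter). For compound 4 the expected value in this assay is 42000 nM, with a range from 18000 nM to 100000 nM.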

Compound 4, half-maximal inhibitory concentration: 28400 nM
Compound 4: the middle estimate sits 1.5-fold (0.17 log units) above what was measured; measured number inside the range.
By their numbers in this assay, from the lowest: compounds 4, 2, 3 and 1 (each within the scatter of the next).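

In this assay, the 3-methoxyphenyl group brings an oxygen onto this ring and, unlike the ring of compound 3, carries no halogen, yet the step stays within the scatter (a 1.6-fold lower number from compound 3 to compound 4 (0.20 log units; within the scatter)). The comparisons with the two simpler rings also stay within the scatter (a 1.0-fold lower number from compound 2 to compound 4 (0.01 log units; within the scatter) and a 1.8-fold lower number from compound 1 to compound 4 (0.26 log units; within the scatter)), so at this amide-type nitrogen these four aryl groups cannot be told apart, even with a hydrogen-bond acceptor now added to the set. No measurement at hand offers an explanation for this flat readout.

Every aryl group shown is a six-membered aromatic ring of carbon only, so it remains open whether a ring bearing an amine or a carboxylic acid, or a longer alkyl chain in place of the ring, would give a step beyond the scatter. All four compounds also share the same core, so these numbers say nothing about how a change elsewhere in the molecule would read in this assay.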